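Swapping 3-nitrophenyl for 4-nitrophenyl in compound 3

The source may hold more compounds than are shown below. What is called first, only, known or untested is meant among the compounds shown, and "the series" means these compounds.

Values measured in a functional assay on K562 cells (Homo sapiens) for cytotoxicity, read by sulforhodamine B assay (on this read-out higher numbers stand for weaker inhibition of growth and lower numbers for stronger inhibition of growth), follow.
Compound 1 (`CC1=CC[C@@H]([C@@](C)(O)CCCC(C)(C)NC(=S)N/N=C\c2ccc(C)cc2)CC1`): 140 nM
Compound 2 (`CC1=CC[C@@H]([C@@](C)(O)CCCC(C)(C)NC(=S)N/N=C\c2ccc(O)cc2)CC1`): 600 nM
Compound 3 (`CC1=CC[C@@H]([C@@](C)(O)CCCC(C)(C)NC(=S)N/N=C\c2cccc([N+](=O)[O-])c2)CC1`): 20 nM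

Compound 3 has the lowest number of the three, clear of the scatter from both others. Compound 4 (`CC1=CC[C@@H]([C@@](C)(O)CCCC(C)(C)NC(=S)N/N=C\c2ccc([N+](=O)[O-])cc2)CC1`) carries 4-nitrophenyl in place of 3-nitrophenyl on a carbon with a double bond to nitrogen. Two measured steps changed that same group (a 7.0-fold lower number from compound 1 to compound 3 (0.85 log units; beyond the scatter); a 30-fold lower number from compound 2 to compound 3 (1.48 log units; beyond the scatter)), and both went beyond the scatter. Among the measured compounds shown here, no measured pair compares these two groups directly. With compound 3 at the low end, a modest move to a higher number in this assay is expected. The expected step is a 2.5-fold higher number from compound 3 to compound 4 (0.40 log units; beyond the scatter) and it remains an estimate. Compound 4 is expected at 50 nM (estimated range 15 nM to 170 nM).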

Compound 4, concentration for 50% growth inhibition: 4220 nM
Compound 4: middle estimate off by 84-fold (1.93 log units), on the low side; the measured number lies above the stated range.
By their numbers in this assay, from the lowest: compound 3; then compound 1; then compound 2; then compound 4.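

In this assay, 4-nitrophenyl in place of 3-nitrophenyl gives a 210-fold higher number from compound 3 to compound 4 (2.32 log units; beyond the scatter) with the same atoms joined differently, so the ring's substitution pattern matters here as well as the identity of the group. Nitro in place of methyl gives a 30-fold higher number from compound 1 to compound 4 (1.48 log units; beyond the scatter) and nitro in place of hydroxy gives a 7.0-fold higher number from compound 2 to compound 4 (0.85 log units; beyond the scatter) on this read-out, so a nitrophenyl group does not by itself bring the low number of compound 3. Nothing shown explains this reversal. Still open, as far as these compounds go, is how 3-aminophenyl or 4-aminophenyl would fall, and whether 3-carboxyphenyl would follow 3-nitrophenyl.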